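The source may hold more compounds than are shown below. What is called first, only, known or untested is meant among the compounds shown, and "the series" means these compounds.

In an ADME assay on Raji cells (Homo sapiens) for cytotoxicity, with a stated time of 72 h (a lower number here means that less compound is needed, a higher number that more compound is needed for the effect), three amides built on closely related cores have been examined so far. Compound 1 `O=C(Nc1ccc(Cl)c(-c2nc3ccccc3s2)c1)c1cc([N+](=O)[O-])ccc1Cl` reaches only a limit there, > 25000 nM. Compound 2 `COc1ccc(-c2nc3ccccc3s2)cc1NC(=O)c1cc([N+](=O)[O-])ccc1Cl` likewise gives a limit, > 25000 nM. Compound 3 `COc1ccc(NC(=O)c2cc([N+](=O)[O-])ccc2Cl)cc1-c1nc2ccccc2s1` also stops at a limit, > 25000 nM. Compounds 2 and 3 have the same atoms joined differently; the difference between the two cores is not broken down here. From compound 3 to compound 1 the change is chloro in place of methoxy on an aromatic carbon, and the step that the two limits leave unreadable from compound 3 to compound 1. Compound 4 `O=C(Nc1cc(-c2nc3ccccc3s2)ccc1Cl)c1cc([N+](=O)[O-])ccc1Cl` remains to be measured in this assay. From compound 2 to compound 4 the change is chloro in place of methoxy on an aromatic carbon, the same kind of change rather than the same one, since here the carbon is ortho to a large group and para to the 1,3-benzothiazol-2-yl group, whereas for compound 1 it is ortho to that group and para to a large group. Because every value shown sits at the limit of > 25000 nM in this assay, at which 3 of the 3 values shown sit, the expected step is a step that the limit leaves unreadable from compound 2 to compound 4. Compound 4 is therefore estimated at 30000 nM, within 12000 nM to 100000 nM.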

Compound 4, half-maximal effective concentration: > 25000 nM
Compound 4: a limit, no number; the forecaster's own chance of this, stated with the estimate: 85%; the middle value is on the limit's open side.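

In this assay compound 4 also gives only a limit, > 25000 nM, so no step can be read from compound 2 to compound 4: the limit of > 25000 nM in this assay, at which 4 of the 4 values shown sit. The compounds shown leave open whether chloro in place of methoxy changes the value at all.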